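Trading a Carbamate Arm for a Phenyl Tail

A few compounds are considered here, and "the series" means these few. Any claim that something is new, unique, unknown or untested is made for them only; others in the source may bear on it.

Compound 1, `CC1=C(N2CC2)C(=O)C(CC(C)OC(N)=O)=C(N2CC2)C1=O`, is the most potent of three related compounds tested in a functional assay on L1210 cells (Mus musculus), with a stated time of 12 days (on this read-out lower numbers stand for lower potency and higher numbers for higher potency (the scale is a negative logarithm)), where compound 1 gives 5.79. Compound 3, `COCCC1=C(N2CC2)C(=O)C(CCOC)=C(N2CC2)C1=O`, follows with 5.31, and compound 2, `CCCC1=C(N2CC2)C(=O)C(CCC)=C(N2CC2)C1=O`, trails with 4.44; both sit beyond the usual scatter from compound 1. The next compound, compound 4, `CC1=C(N2CC2)C(=O)C(CCCc2ccccc2)=C(N2CC2)C1=O`, differs from compound 1 in one place: a group of 8 heavy atoms (8 carbon; one six-membered aromatic ring of carbon only) in place of a group of 6 heavy atoms (3 carbon, 1 nitrogen, 2 oxygen; no ring), on a saturated chain carbon bound to a double-bonded ring carbon. Going by the values given here, no measured pair shows this exact change, but compound 2 carries plain carbon chains and gives the lowest number, so a drop is expected rather than a gain. The expected step from compound 1 to compound 4 in this assay is a number 0.89 log units lower from compound 1 to compound 4 (beyond the scatter), beyond the scatter. Compound 4 is therefore estimated at 4.9, within 4.3 to 5.5.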

Compound 4, logarithm of the reciprocal of the active concentration, log(1/C): 4.21
Compound 4: the middle estimate sits 0.69 log units above what was measured, and the stated range ends above it.
By their numbers in this assay, from the lowest: compounds 4 and 2 (each within the scatter of the next); then compound 3; then compound 1.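

In this assay, replacing the carbamate arm with phenethyl, on a saturated chain carbon bound to a double-bonded ring carbon, gives a number 1.58 log units lower from compound 1 to compound 4 (beyond the scatter) in a single change. This position is therefore far from indifferent to what it carries, and a phenyl-bearing carbon tail with no hydrogen-bond donors or acceptors does not keep the potency of compound 1. Nothing available here gives a reason for this loss.
The compounds shown leave open whether the loss goes with removing the carbamate or with adding the phenyl ring. A plain ethyl group, an amine or a carboxylic acid at this place could help separate the two.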